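Moving the Nitrile on the Sulfonyl Aryl Group

This account rests on a few compounds, and the source may have more. Where it says the series, first, only, none or still open, it means among the compounds named here.

Compound 1 `CC1CCN(c2c(S(=O)(=O)c3ccc(C#N)cc3)cnc3cc(F)ccc23)CC1`: 83%
Compound 2 `COc1ccc(S(=O)(=O)c2cnc3ccc(OC)cc3c2N2CCC(C)CC2)cc1`: 41%
Compound 3 `Cc1cc(C)cc(S(=O)(=O)c2cnc3cc(F)ccc3c2N2CCC(C)CC2)c1`: 80%

All three compounds were tested in an assay on isolated protein for displacement of a labelled ligand from metabotropic glutamate receptor 5 (Homo sapiens), with a stated time of 60 min, tested at 1 uM; on this read-out higher numbers stand for more inhibition at the one concentration tested (going by the name of the read-out) and lower numbers for less inhibition. Compound 3 stands second highest of the three numbers. Its nearest neighbour is compound 1, higher by a step within the scatter, so the two cannot be told apart. Going by the values given here, compound 2 lies far below, beyond the scatter, but it differs from compound 3 in more than one place, so no single step connects them.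

Compound 4 `CC1CCN(c2c(S(=O)(=O)c3cccc(C#N)c3)cnc3cc(F)ccc23)CC1` is the next compound. Compared with compound 3 the change is 3-cyanophenyl in place of 3,5-dimethylphenyl on a sulfonyl sulfur. Among the compounds with values here, the one measured step that bears on this is a number 3 percentage points lower from compound 1 to compound 3 (within the scatter), which also swapped the group on the sulfonyl sulfur, between a 4-cyanophenyl and a 3,5-dimethylphenyl, and produced no change beyond the scatter. A nitrile-bearing phenyl has therefore already been seen to do as well as the dimethylphenyl here, and the step is expected to be small: a number 2 percentage points lower from compound 3 to compound 4 (within the scatter). For compound 4 the estimate in this assay is 78%, with a range from 60% to 90%.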

Compound 4, a percentage reported as inhibition, at one concentration (the size of the read-out at that concentration, not a potency): 92%
Beside the measured number, compound 4's estimate is 14 percentage points below it, and the stated range ends below it.
By their numbers in this assay, from the lowest: compound 2; then compounds 3, 1 and 4 (each within the scatter of the next, the first and the last beyond it).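

In this assay, the change on the sulfonyl sulfur gives a number 12 percentage points higher from compound 3 to compound 4 (beyond the scatter), so the group at this place can shift the read-out by more than the scatter, which the step between compound 1 and compound 3 had not shown. Moving the nitrile gives a number 9 percentage points higher from compound 1 to compound 4 (within the scatter), so 3-cyanophenyl and 4-cyanophenyl cannot be told apart here, and compound 1 lies within the scatter of both compound 3 and compound 4; only the 3-cyanophenyl stands clear of the 3,5-dimethylphenyl, and the 4-cyanophenyl does not. Nothing available here accounts for the gap between the 3-cyanophenyl and the 3,5-dimethylphenyl.

The compounds shown leave open whether a phenyl carrying a carboxylic acid or an amine in place of the nitrile, or a longer chain ending in a nitrile, would keep the read-out at this level. As far as these compounds go, a reading at one concentration is also not a potency, so how compound 1 and compound 4 compare across a range of concentrations remains open.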